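Swapping chloro for methyl on a hydrazone series

A few compounds are considered here, and "the series" means these few. Any claim that something is new, unique, unknown or untested is made for them only; others in the source may bear on it.

Measured so far:
compound 1 `O=C(COc1cccc2ccccc12)N/N=C/c1ccc(Cl)cc1`: 100 ug/mL
compound 2 `C/C(=N\NC(=O)COc1cccc2ccccc12)c1cccc([N+](=O)[O-])c1`: 20 ug/mL
compound 3 `COc1cc(/C=N/NC(=O)COc2cccc3ccccc23)cc(OC)c1O`: 100 ug/mL

These three compounds share one core and were tested in an ADME assay on HEL cells (Homo sapiens) for cytotoxicity; on this read-out lower numbers stand for higher toxicity in this test and higher numbers for lower toxicity in this test. Compound 1 gives 100 ug/mL there, level with compound 3 at the digits shown; together the two sit at the highest number of the three. Compound 2 stands furthest from compound 1, with a lower number that lies beyond the usual scatter.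

Compound 4 `Cc1ccc(/C=N/NC(=O)COc2cccc3ccccc23)cc1` has not yet been measured. It differs from compound 1 in one place: methyl in place of chloro on an aromatic carbon. Cut one bond further out, the change runs from 4-chlorophenyl to 4-methylphenyl; nothing else in the molecule moves, no ring is added or lost, and the count of hydrogen-bond donors and acceptors is unchanged.

Going by the values given here, no step between two measured compounds shows this exact swap, so the expectation rests on the small size of the change alone. The step of no change at the digits printed from compound 1 to compound 4 (within the scatter) is expected to be none beyond the scatter, in either direction. Compound 4 is therefore estimated at 100 ug/mL in this assay, within a range from 40 ug/mL to 200 ug/mL.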

Compound 4, minimum cytotoxic concentration: 20 ug/mL
The estimate for compound 4 lay 5.0-fold (0.70 log units) above the measured number; measured number outside the range, below it.
By their numbers in this assay, from the lowest: compounds 2 and 4 (each within the scatter of the next); then compounds 1 and 3 (each within the scatter of the next).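

In this assay, exchanging a single heavy atom on an aromatic carbon para to a large group gives a 5.0-fold lower number from compound 1 to compound 4 (0.70 log units; beyond the scatter) and so shows that this position is sensitive to the change. Methyl in place of chloro leaves the ring count, the hydrogen-bond donors and acceptors, and the net charge as they were, yet the number still moves beyond the usual scatter, towards higher toxicity in this test. Nothing measured here explains why the number moves.

Whether this step comes from gaining methyl or from losing chloro stays open, as the compounds shown hold no other group at this position, such as fluoro, an amine or a carboxylic acid. From the compounds shown here alone, whether the same swap would give a similar step elsewhere also stays open.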